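Benzyl in Place of Benzyloxy: What Compound 3 May Tolerate

The source may hold more compounds than are shown below. What is called first, only, known or untested is meant among the compounds shown, and "the series" means these compounds.

Measured compounds:
Compound 1: `CC(C)(C)OC(=O)Nc1ncc(C(Oc2ccc(Br)cc2)c2ccc(Cl)cc2)s1` — in an ADME assay on HepG2 2.2.15 cells (Homo sapiens) for cytotoxicity (a higher number here means that more compound is tolerated, a lower number that less compound is tolerated), compound 1 gives > 50000 nM, a limit of the assay.
Compound 2: `CC(C)(C)OC(=O)Nc1ncc(C(Oc2ccc(OCc3ccccc3)cc2)c2ccc(Cl)cc2)s1` — in this assay compound 2 gives > 50000 nM, a limit of the assay.

Among the measured compounds shown here, compound 2 stands at the limit, and the one other value shown sits at the same limit, as stated by the limit of > 50000 nM in this assay, at which 2 of the 2 values shown sit. For the measured compounds named here, the only step between measured compounds, a step that the two limits leave unreadable from compound 1 to compound 2, therefore cannot be read for size. Both of its ends are limits rather than numbers.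

Compound 3, `CC(C)(C)OC(=O)Nc1ncc(C(Oc2ccc(Cc3ccccc3)cc2)c2ccc(Cl)cc2)s1`, differs from compound 2 by benzyl in place of benzyloxy on an aromatic carbon. Going by the values given here, the single measured step bears on this change only in that it shows a different group at this same position being tolerated up to the limit; its size stays unreadable, so no direction can be taken from it. With nothing pointing to a change beyond the scatter, compound 3 is expected to stay at or near the limit as well. The expected step is a step that the limit leaves unreadable from compound 2 to compound 3. Compound 3 is estimated to give 60000 nM, within a range from 20000 nM to 200000 nM.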

Compound 3, half-maximal cytotoxic concentration: > 50000 nM
Compound 3: no number, only a limit (the forecaster's own chance of this, stated with the estimate: 75%); the middle value lies beyond the limit too.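

Compound 3 also sits at a limit of the assay, so its steps from compound 1 and compound 2 cannot be read for size: the limit of > 50000 nM in this assay, at which 3 of the 3 values shown sit. The compounds shown leave open at what concentration compound 1, compound 2 or compound 3 would harm the cells in this assay, and whether bromo, benzyloxy and benzyl differ at all.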